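A few compounds are considered here, and "the series" means these few. Any claim that something is new, unique, unknown or untested is made for them only; others in the source may bear on it.

Measured in a functional assay on HeLa cells (Homo sapiens) for cytotoxicity, read by MTT assay; on this read-out higher numbers stand for weaker inhibition and lower numbers for stronger inhibition:
- compound 1 `CC(C)=CC[C@@H](OC(=O)CCO)C1=CC(=O)c2c(O)ccc(O)c2C1=O`: 67600 nM
- compound 2 `CC(=O)OCCC(=O)O[C@H](CC=C(C)C)C1=CC(=O)c2c(O)ccc(O)c2C1=O`: 17300 nM
- compound 3 `CC(C)=CC[C@@H](OCC(C)O)C1=CC(=O)c2c(O)ccc(O)c2C1=O`: 24700 nM

Compound 3 stands level with one neighbour, a 1.4-fold higher number from compound 2 to compound 3 (0.15 log units; within the scatter), and clear of the other, a 2.7-fold lower number from compound 1 to compound 3 (0.44 log units; beyond the scatter). Compound 4 `CCC(CO[C@H](CC=C(C)C)C1=CC(=O)c2c(O)ccc(O)c2C1=O)OC(C)=O` carries a further change: 1-acetoxypropyl in place of 1-hydroxyethyl on a saturated chain carbon bound to an oxygen on a saturated carbon, which is 1-acetoxypropyl in place of 1-hydroxyethyl on a saturated chain carbon bound to an oxygen on a saturated carbon. The nearest measured precedent is acetyl in place of hydrogen on an oxygen on a saturated carbon, a modest step of a 3.9-fold lower number from compound 1 to compound 2 (0.59 log units; beyond the scatter). Going by the values given here, no measured step covers the longer chain. A modest move towards lower numbers in this assay is therefore expected, and the estimated step is a 2.5-fold lower number from compound 3 to compound 4 (0.39 log units; beyond the scatter). For compound 4 the expected value is 10000 nM, with an estimated range of 4000 nM to 25000 nM.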

Compound 4, half-maximal inhibitory concentration: 44000 nM
Estimate against measurement, compound 4: 4.4-fold (0.64 log units) below, outside the stated range (above it).
By their numbers in this assay, from the lowest: compounds 2, 3, 4 and 1 (each within the scatter of the next, the first and the last beyond it).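

In this assay, acetyl on this chain does not repeat the clear step seen on the ester chain, a 3.9-fold lower number from compound 1 to compound 2 (0.59 log units; beyond the scatter): here the change gives a 1.8-fold higher number from compound 3 to compound 4 (0.25 log units; within the scatter). With acetoxy on both chains, 2-acetoxybutyl in place of (2-acetoxyethyl)carbonyl gives a 2.5-fold higher number from compound 2 to compound 4 (0.41 log units; beyond the scatter), whereas in place of (2-hydroxyethyl)carbonyl it gives a 1.5-fold lower number from compound 1 to compound 4 (0.19 log units; within the scatter). No measurement offered here accounts for this difference between the chains. The compounds shown leave open how the acetyl and the longer chain each contribute, as the two changes arrive together. A 2-acetoxypropyl or a 2-hydroxybutyl group on that oxygen would separate them.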